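Amino for ethyl on the aryl ring of a chloropyridine tetrazolyl amide

The source may hold more compounds than are shown below. What is called first, only, known or untested is meant among the compounds shown, and "the series" means these compounds.

Measured compounds:
compound 1, `COc1cccc(-c2cc(Cl)cc(C(=O)Nc3nn[nH]n3)n2)c1`, 95%
compound 2, `CCc1ccc(-c2cc(Cl)cc(C(=O)Nc3nn[nH]n3)n2)cc1`, 100%

In a functional assay on the whole organism with Rattus norvegicus as the target, at a dose of 3 mg/kg by the oral route (a lower number here means a weaker effect, a higher number a stronger effect of the compound at the dose given), compound 1 gives 95% and compound 2 gives 100%. The two numbers lie within the scatter of each other, so the two measured compounds are not told apart by this assay; compound 2 simply carries the number that serves as the reference for the step that follows.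

Compound 3, `Nc1ccc(-c2cc(Cl)cc(C(=O)Nc3nn[nH]n3)n2)cc1`, has not been measured in this assay. It differs from compound 2 in one place: amino in place of ethyl on an aromatic carbon. Going by the values given here, no measured pair shows the effect of such a swap, so the size of the step is uncalibrated. Given that both measured compounds sit close to full inhibition at this dose, the step from compound 2 to compound 3 is expected to be small or none beyond the scatter, a number 15 percentage points lower from compound 2 to compound 3 (beyond the scatter), with the risk lying on the downward side. For compound 3 the estimate in this assay is 85%, in the range 55% to 100%.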

Compound 3, a percentage reported as inhibition, in the whole organism at one dose (the size of the read-out at that dose, not a potency): 100%
For compound 3 the middle estimate is 15 percentage points below the measured one, within the range that was stated.
By their numbers in this assay, from the lowest: compounds 1, 2 and 3 (each within the scatter of the next).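

In this assay, amino in place of ethyl on the aromatic carbon para to a large group gives no change at the digits printed from compound 2 to compound 3 (within the scatter). This position of the aryl ring therefore accepts a nitrogen-linked group carrying a hydrogen-bond donor as well as a two-carbon chain without a step that can be read at this dose, which compounds 1 and 2 alone could not show. Nothing available bears on the reason for this result.

As far as these compounds go, since the read-out is the size of the effect at one dose and not a potency, any difference between compound 2 and compound 3 at other doses remains open. Also open, from the compounds shown here alone, is whether a carboxylic acid or a longer alkyl chain at this position would keep the read-out of compound 3.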